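Swapping one aryl group on compound 3

A few compounds are considered here, and "the series" means these few. Any claim that something is new, unique, unknown or untested is made for them only; others in the source may bear on it.

In a functional assay on MDA-MB-231 cells (Homo sapiens) for cytotoxicity, read by MTT assay, with a stated time of 48 h (a higher number here means a weaker inhibitor, a lower number a stronger inhibitor), compound 1 `COc1cc(C2=NOC(c3cc(OC)c(OC)c(OC)c3)C2)ccc1O` gives 3600 nM and compound 2 `COc1ccc(C2=NOC(COc3ccc(-c4nnnn4-c4cc(OC)c(OC)c(OC)c4)cc3N)C2)cc1O` gives 3380 nM while compound 3 `COc1cc(C2=NOC(COc3ccc(-c4nnnn4-c4cc(OC)c(OC)c(OC)c4)cc3N)C2)ccc1O` gives 3620 nM as its reading. These three numbers lie within the usual scatter of one another, so compound 3 stands level with the other two and no ranking can be drawn.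

Compound 4 `COc1cc(-n2nnnc2-c2ccc(OCC3CC(c4ccccc4F)=NO3)c(N)c2)cc(OC)c1OC` differs from compound 3 in one group 2-fluorophenyl in place of 4-hydroxy-3-methoxyphenyl on a carbon with a double bond to nitrogen with 2-fluorophenyl in place of 4-hydroxy-3-methoxyphenyl on a carbon with a double bond to nitrogen.

Among the measured compounds shown here, the one measured step at this place is a 1.1-fold higher number from compound 2 to compound 3 (0.03 log units; within the scatter) and it merely trades 3-hydroxy-4-methoxyphenyl for 4-hydroxy-3-methoxyphenyl. For the measured compounds named here, no measured compound carries 2-fluorophenyl, so the data offer no direction for this larger swap. The expected change is therefore none beyond the scatter, with the estimate at a 1.2-fold lower number from compound 3 to compound 4 (0.08 log units; within the scatter) and real uncertainty around it. Compound 4 is estimated at 3000 nM (expected range 900 nM to 10000 nM).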

Compound 4, half-maximal inhibitory concentration: 2400 nM
Beside the measured number, compound 4's estimate is 1.3-fold (0.10 log units) above it, within the range that was stated.
By their numbers in this assay, from the lowest: compounds 4, 2, 1 and 3 (each within the scatter of the next).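

On the carbon with a double bond to nitrogen, 2-fluorophenyl in place of 4-hydroxy-3-methoxyphenyl gives a 1.5-fold lower number from compound 3 to compound 4 (0.18 log units; within the scatter) in this assay, and 2-fluorophenyl in place of 3-hydroxy-4-methoxyphenyl gives a 1.4-fold lower number from compound 2 to compound 4 (0.15 log units; within the scatter) in the same test. Among the compounds shown here, this is the first sign that the position tolerates a quite different ring: 4-hydroxy-3-methoxyphenyl carries a hydrogen-bond donor and acceptors, 2-fluorophenyl carries none, and the readings still stay within the scatter. No independent measurement here accounts for this flat result.

Still open, from the compounds shown here alone, is whether any group at this carbon can move the number beyond the scatter, for example a small methyl or a pyridine ring. A plain phenyl or a 2-chlorophenyl would also show whether the fluorine itself matters here.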